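This account rests on a few compounds, and the source may have more. Where it says the series, first, only, none or still open, it means among the compounds named here.

Three compounds share one core and differ only in the aryl group on the aromatic carbon. Compound 1 `N#Cc1cccc(-c2ccc(Cl)c(C(=O)NCC3(O)CCCCCC3)c2)n1` gives 232 nM in a functional assay on HEK293 cells for antagonist activity at P2X purinoceptor 7 (Homo sapiens); on this read-out higher numbers stand for weaker inhibition and lower numbers for stronger inhibition. Compound 2 `O=C(NCC1(O)CCCCCC1)c1cc(-c2ccc(CO)cn2)ccc1Cl` gives 17 nM in this assay. Compound 3 `COc1ccc(-c2ccc(Cl)c(C(=O)NCC3(O)CCCCCC3)c2)nc1` gives 213 nM in this assay, the second highest of the three numbers: compound 1 sits within the scatter of it, while compound 2 lies far off, a 13-fold higher number from compound 2 to compound 3 (1.10 log units; beyond the scatter). The step of a 1.1-fold lower number from compound 1 to compound 3 (0.04 log units; within the scatter) and the step of a 14-fold lower number from compound 1 to compound 2 (1.14 log units; beyond the scatter) show the same picture: the hydroxymethyl compound stands apart, the methoxy and cyano compounds come out alike.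

Compound 4 `O=C(NCC1(O)CCCCCC1)c1cc(-c2ccc(Cl)cn2)ccc1Cl` is not yet measured. Relative to compound 3, (chloro in place of methoxy on an aromatic carbon). Among the compounds with values here, no measured step swaps methoxy for chloro. Within the data shown here, the one step that touches the methoxy is a 13-fold higher number from compound 2 to compound 3 (1.10 log units; beyond the scatter), and it concerns hydroxymethyl, not chloro, so it gives no direction here. Since methoxy and cyano were alike, a small shift at most is expected from replacing methoxy with chloro. Compound 4 is therefore estimated at 250 nM, with a range of 80 nM to 800 nM. The expected step is a 1.2-fold higher number from compound 3 to compound 4 (0.07 log units; within the scatter), within the scatter.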

Compound 4, half-maximal inhibitory concentration: 56 nM
The estimate for compound 4 lay 4.5-fold (0.65 log units) above the measured number; the whole stated range lies above it.
By their numbers in this assay, from the lowest: compound 2; then compound 4; then compounds 3 and 1 (each within the scatter of the next).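

Chloro in place of methoxy is not a neutral change at this place on the ring: a 3.8-fold lower number from compound 3 to compound 4 (0.58 log units; beyond the scatter) in this assay shows that a lower number here does not depend on hydroxymethyl alone, although chloro brings 0 hydrogen-bond donors. Hydroxymethyl still gives the lowest number of the series, with a 3.3-fold higher number from compound 2 to compound 4 (0.52 log units; beyond the scatter) marking a gap to chloro beyond the scatter, while a 4.1-fold lower number from compound 1 to compound 4 (0.62 log units; beyond the scatter) also sets 5-chloropyridin-2-yl apart from 6-cyanopyridin-2-yl and leaves compound 4 in the middle of the series. Nothing available explains why these groups separate in this way.

As far as these compounds go, it remains open whether an amine, a carboxylic acid or a longer hydroxyalkyl chain at this place would fall nearer compound 2 or compound 4. The compounds shown also leave open how a nitrile would behave on the same ring carbon as chloro, since the nitrile of compound 1 sits elsewhere on the ring.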